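Series notes: carbamate to thiocarbonyl change on the ring amine

This account rests on a few compounds, and the source may have more. Where it says the series, first, only, none or still open, it means among the compounds named here.

Measured so far:
compound 1, `CC(C)OC(=O)N1CCC(Oc2cccc3c2CCN3c2ccc(S(C)(=O)=O)cc2)CC1`, 70%
compound 2, `CC(C)(C)OC(=O)N1CCC(Oc2ncnc3c2CCN3c2ccc(S(C)(=O)=O)cc2F)CC1`, 139%

In a functional assay on CHO-K1 cells with Glucose-dependent insulinotropic receptor (Homo sapiens) as the target, read by a luciferase reporter, with a stated time of 5 h (a lower number here means a smaller maximal response, a higher number a larger maximal response), compound 2 gives 139%, the highest of the two numbers available; the nearest is compound 1, whose value in this assay is 70%, a gap that lies beyond the usual scatter. Going by the values given here, no pair of measured compounds differs in only one place, so no single-point step has been measured in this set.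

Compound 3 is `CS(=O)(=O)c1ccc(N2CCc3c(OC4CCN(C(=S)Sc5ccccc5)CC4)ncnc32)c(F)c1`, not yet measured. It differs from compound 2 as follows: a group of 9 heavy atoms (7 carbon, 2 sulfur; one six-membered aromatic ring of carbon only) in place of a group of 7 heavy atoms (5 carbon, 2 oxygen; no ring), on an amine nitrogen in a ring. The tert-butoxycarbonyl leaves, and a group carrying one six-membered aromatic ring of carbon only enters on the amine nitrogen in the ring.

Nothing measured here speaks directly to this exchange, so the expected step in this assay is uncertain; a moderate decrease from the high maximal response of compound 2 is taken as the central expectation, with no change beyond the scatter also plausible. The expected step is a number 34 percentage points lower from compound 2 to compound 3 (beyond the scatter). For compound 3 the estimate in this assay is 105%, with a range from 55% to 150%.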

Compound 3, largest response reached (reported as percent of maximum), in percent of the reference or control that the assay uses: 103%
For compound 3 the middle estimate is 2 percentage points above the measured one; measured number inside the range.
By their numbers in this assay, from the lowest: compound 1; then compound 3; then compound 2.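

In this assay, going by these compounds alone, the amine nitrogen in the ring gives the first single-place step in this set: a number 36 percentage points lower from compound 2 to compound 3 (beyond the scatter), a large change, so the group on this nitrogen affects the maximal response while the rest of compound 2 stays fixed. The exchange lowers the response without abolishing it, as compound 3 gives 103% with the sulfur-containing aromatic group in place of tert-butoxycarbonyl. Nothing available here explains the size of this step.

The exchange alters the sulfur atoms and the aromatic ring together, leaving their separate contributions unresolved. A phenoxycarbonyl group, which keeps the aromatic ring with oxygen in place of sulfur, or a urea on the same nitrogen would show how the response depends on each part of the group.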